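The source may hold more compounds than are shown below. What is called first, only, known or untested is meant among the compounds shown, and "the series" means these compounds.

Compound 1 `Cc1nn(-c2ccccc2)c2nc(OCc3ccccc3F)c(-c3nc(N)cc(N)n3)cc12`: 2200 nM
Compound 2 `Cc1nn(-c2ccccc2)c2nc(OCc3ccccc3F)c(-c3nc(N)c4c(n3)[nH]c(=O)n4C)cc12`: 4900 nM

In a functional assay on aorta (Rattus norvegicus, strain Sprague-Dawley) (a higher number here means that more compound is needed for the effect, a lower number that less compound is needed), compound 1 holds the lower of the two numbers, at 2200 nM, and compound 2 holds the higher, at 4900 nM.

Compound 3 `Cc1nn(-c2ccccc2)c2nc(OCc3ccc(C(F)(F)F)cc3)c(-c3nc(N)cc(N)n3)cc12` keeps the core of compound 1 and its group on the aromatic carbon, but carries a different benzyl group: 4-(trifluoromethyl)phenyl in place of 2-fluorophenyl on a saturated chain carbon bound to an oxygen on an aromatic ring. This is 4-(trifluoromethyl)phenyl in place of 2-fluorophenyl.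

Among the compounds with values here, only one measured step is available, a 2.2-fold higher number from compound 1 to compound 2 (0.35 log units; beyond the scatter). It is modest and changes a different place, so it gives a rough scale but no direction. Within the data shown here, no measured step touches the 2-fluorobenzyl group.

No shift beyond the scatter is therefore expected in this assay, and the expected step is a 1.1-fold higher number from compound 1 to compound 3 (0.06 log units; within the scatter). For compound 3 the estimated value is 2500 nM, with an expected range of 800 nM to 8000 nM.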

Compound 3, half-maximal effective concentration: 1600 nM
The estimate for compound 3 lay 1.6-fold (0.19 log units) above the measured number; the measured number falls inside the stated range.
By their numbers in this assay, from the lowest: compounds 3 and 1 (each within the scatter of the next); then compound 2.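

In this assay, within the data shown here, the only step at this group is a 1.4-fold lower number from compound 1 to compound 3 (0.14 log units; within the scatter), so compound 1 and compound 3 cannot be told apart here. At this position, on a saturated chain carbon bound to an oxygen on an aromatic ring, 4-(trifluoromethyl)phenyl with 10 heavy atoms reads like 2-fluorophenyl with 7, so this larger group shows no penalty in this assay. Nothing available explains why the two groups read alike.

Still open, from the compounds shown here alone, is whether the position stays this flat for groups of another kind, such as an amine or a carboxylic acid on the phenyl ring, or a longer chain in place of the benzyl carbon. The step also changes both the substituent and its place on the ring, so neither effect can be read alone.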